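The source may hold more compounds than are shown below. What is called first, only, known or untested is meant among the compounds shown, and "the series" means these compounds.

Measured so far in a functional assay on KBVIN cells (Homo sapiens) for antiproliferative activity, read by sulforhodamine B assay, with a stated time of 3 days; on this read-out higher numbers stand for weaker inhibition of growth and lower numbers for stronger inhibition of growth:
- compound 1 `COc1ccc(NC(=O)c2cccc(Nc3ncc(F)c(Nc4ccc(F)cc4)n3)c2)cc1`: 15700 nM
- compound 2 `O=C(Nc1cccc(Nc2ncc(F)c(Nc3ccc(F)cc3)n2)c1)c1cnccn1`: 20100 nM

Compound 2 has a single measured neighbour, and the two numbers cannot be told apart: the series shows a 1.3-fold higher number from compound 1 to compound 2 (0.11 log units; within the scatter). Compound 2 therefore stands level with compound 1 on the present evidence.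

Compound 3 `CN(C)c1ccc(C(=O)Nc2cccc(Nc3ncc(F)c(Nc4ccc(F)cc4)n3)c2)cc1` has not yet been measured. It differs from compound 2 as follows: 4-(dimethylamino)phenyl in place of pyrazin-2-yl on a carbonyl carbon. In words, this is 4-(dimethylamino)phenyl in place of pyrazin-2-yl on a carbonyl carbon.

Within the data shown here, only one measured step bears on this change, and only indirectly. It places ((pyrazin-2-yl)carbonyl)amino in place of (4-methoxyphenyl)carbamoyl on an aromatic carbon, and it amounts to a 1.3-fold higher number from compound 1 to compound 2 (0.11 log units; within the scatter). Among the measured compounds shown here, no measured pair isolates the exchange at the carbonyl carbon, so the evidence is thin. With that one small step as the guide, no shift beyond the scatter is expected in this assay, and no direction can be argued with confidence. The expected change is a 1.3-fold lower number from compound 2 to compound 3 (0.10 log units; within the scatter). Compound 3 is estimated at 16000 nM, with an expected range of 7000 nM to 35000 nM.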

Compound 3, concentration for 50% growth inhibition: > 10000 nM
Compound 3: only a limit was reported (the forecaster's own chance of this, stated with the estimate: 10%); the middle value lies beyond the limit too.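

In this assay compound 3 gives > 10000 nM, which is a limit and not a number, so no step can be read from compound 2 to compound 3. The compounds shown leave open whether 4-(dimethylamino)phenyl in place of pyrazin-2-yl on a carbonyl carbon changes growth inhibition at all, and in which direction.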